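Chloro in Place of Fluoro: An Expected Limit Value

The source may hold more compounds than are shown below. What is called first, only, known or untested is meant among the compounds shown, and "the series" means these compounds.

Compound 1 `COc1cc(OC)c2c(=O)cc(-c3ccc(OCc4cn(-c5ccc(F)cc5F)nn4)c(OCc4cn(-c5ccc(F)cc5F)nn4)c3)oc2c1`: > 100 ug/mL
Compound 2 `COc1cc(OC)c2c(=O)cc(-c3ccc(OCc4cn(-c5ccc(F)cc5F)nn4)c(OC)c3)oc2c1`: > 100 ug/mL
Compound 3 `COc1cc(O)c(C(=O)/C=C/c2ccc(OCc3cn(-c4ccccc4Cl)nn3)c(OC)c2)c(OC)c1`: > 100 ug/mL

In an ADME assay on Huh-7 cells (Homo sapiens) for cytotoxicity, read by MTT assay, with a stated time of 72 h (on this read-out higher numbers stand for lower toxicity in this test and lower numbers for higher toxicity in this test), every measured value is a limit of the assay and not a number. Compound 1 sits at that limit. Compound 3 sits at that limit as well. Compound 2 stands where the other two stand, at the limit, so no order among the three can be read (the limit of > 100 ug/mL in this assay, at which 3 of the 3 values shown sit).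

Compound 4 `COc1cc(OC)c2c(=O)cc(-c3ccc(OCc4cn(-c5ccc(F)cc5Cl)nn4)c(OC)c3)oc2c1` has not been measured. It differs from compound 2 by chloro in place of fluoro on an aromatic carbon. Among the compounds with values here, no step between measured compounds is available to size this change. With all measured values at the limit, the expected step is a number no higher from compound 2 to compound 4 (the limit leaves the size open), none beyond the scatter. Compound 4 is estimated at 100 ug/mL, between 50 ug/mL and 200 ug/mL, and is expected to be reported again only as a limit.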

Compound 4, half-maximal cytotoxic concentration: > 100 ug/mL
Compound 4 was reported as a limit (the forecaster's own chance of this, stated with the estimate: 85%); the middle value sits exactly at the limit.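

Compound 2 and compound 4 are both reported only as limits, so no step can be read between them: the limit of > 100 ug/mL in this assay, at which 4 of the 4 values shown sit.

The compounds shown leave open whether chloro in place of fluoro changes the result in this assay at all, and where any of these compounds would give a true number.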